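This account rests on a few compounds, and the source may have more. Where it says the series, first, only, none or still open, it means among the compounds named here.

Compound 1 `CSc1ncnc2c1c(-c1ccccc1)cn2[C@@H]1O[C@H](CO)[C@@H](O)[C@H]1O` in a functional assay on CEM-DNR-bulk cells (Homo sapiens), read by MTT assay, with a stated time of 72 h (a higher number here means a weaker inhibitor, a lower number a stronger inhibitor), gives only a limit, > 20000 nM. Compound 2 `COc1ncnc2c1c(-c1cccs1)cn2[C@@H]1O[C@H](CO)[C@@H](O)[C@H]1O` in this assay gives 12100 nM. Compound 3 `CNc1ncnc2c1c(-c1cccs1)cn2[C@@H]1O[C@H](CO)[C@@H](O)[C@H]1O` in this assay gives only a limit, > 20000 nM.

Compound 3 thus stands at the limit of the assay, where compound 1 also sits (the limit of > 20000 nM in this assay, at which 2 of the 3 values shown sit); only compound 2 yields a number. The unmeasured compound 4 `CSc1ncnc2c1c(-c1cccs1)cn2[C@@H]1O[C@H](CO)[C@@H](O)[C@H]1O` differs from compound 3 in one place (methylsulfanyl in place of methylamino on an aromatic carbon). For the measured compounds named here, the only measured step at this position, an at least 1.6-fold higher number from compound 2 to compound 3 (0.21 log units; that floor lies within the scatter), carried the value to the limit, and compound 1, which also carries methylsulfanyl, lies at the limit as well. No step beyond the scatter is therefore expected for compound 4. Its value in this assay is estimated at 25000 nM, between 8000 nM and 60000 nM, most likely reported again only as a limit. The expected step that the limit leaves unreadable from compound 3 to compound 4 lies within the scatter.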

Compound 4, half-maximal inhibitory concentration: > 20000 nM
Compound 4 gave a limit, no number; the forecaster's own chance of this, stated with the estimate: 70%; the middle value is on the limit's open side.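

Methylsulfanyl in place of methoxy on this aromatic carbon gives an at least 1.6-fold higher number from compound 2 to compound 4 (0.21 log units; that floor lies within the scatter). The steps to compound 4 from compound 3 and from compound 1 cannot be read, as both ends of each are limits, so neither the change from methylamino nor that from phenyl to thiophen-2-yl can be sized. Compound 2, with methoxy, is now the only compound with a number, and the rest sit at the limit: the limit of > 20000 nM in this assay, at which 3 of the 4 values shown sit.

Going by these compounds, it remains open whether an amino group, a chlorine or a longer alkoxy chain on this aromatic carbon would give a number in this assay, and whether that number would lie beyond the scatter from compound 2.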